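The compounds below may be only part of what the source reports. "The series", "measured", "known", "first", "only" and "open" are said of these compounds alone.

Compound 1 `C[C@@H]1CC(c2cnc3c(C#N)nn([C@H](C)c4ccc(Cl)cc4Cl)c3n2)=CC[C@@H]1N1CCC[C@H]1C(C)(C)O`: 384 nM
Compound 2 `CC1CN(c2cnc3cnn(C(C)c4ccc(Cl)cc4Cl)c3n2)CCC1N1CCCCC1`: 238 nM
Compound 3 `Cc1nn([C@H](C)c2ccc(Cl)cc2Cl)c2nc(N3CC[C@H](N4CCCCCC4)[C@H](C)C3)cnc12`: 23 nM

These three compounds were tested in a functional assay on cells for antagonist activity at C-C chemokine receptor type 4 (Homo sapiens), read by fluorescence and calcium flux, with stated times of 2.5 s and 45 s; on this read-out lower numbers stand for stronger inhibition and higher numbers for weaker inhibition. Compound 3 gives the lowest number of the three; compound 2 sits higher, compound 1 higher still, and both gaps lie well beyond the ordinary scatter of repeated runs. Compound 4 `Cc1nn([C@H](C)c2ccc(Cl)cc2Cl)c2nc(N3CC[C@H](N4CCCCC4)[C@H](C)C3)cnc12` has not yet been measured. It keeps the whole framework of compound 3 and changes a single group (piperidin-1-yl in place of azepan-1-yl on a saturated ring carbon). Among the measured compounds shown here, no measured pair shows this exact change in isolation, so its effect can only be guessed. A modest loss in potency, close to the edge of the scatter, is the expected outcome, a 1.7-fold higher number from compound 3 to compound 4 (0.24 log units; within the scatter). Compound 4 is thus estimated at 40 nM, with a plausible range from 15 nM to 120 nM.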

Compound 4, half-maximal inhibitory concentration: 42 nM
The estimate for compound 4 lay 1.1-fold (0.02 log units) below the measured number; measured number inside the range.
By their numbers in this assay, from the lowest: compounds 3 and 4 (each within the scatter of the next); then compounds 2 and 1 (each within the scatter of the next).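

In this assay, placing piperidin-1-yl in place of azepan-1-yl on the saturated ring carbon gives a 1.8-fold higher number from compound 3 to compound 4 (0.26 log units; within the scatter). Among the compounds shown here, this is the first direct comparison at this position, and it shows that the six-membered and seven-membered rings cannot be told apart here, with all else held the same. Nothing at hand explains why the two rings read alike. Still open, from the compounds shown here alone, is how an oxygen-containing ring such as morpholin-4-yl, or an open-chain amine such as dimethylamino, would read at this same carbon.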